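The source may hold more compounds than are shown below. What is called first, only, known or untested is meant among the compounds shown, and "the series" means these compounds.

Compound 1 `O=c1ccoc2cc(OCc3cn(Cc4cccc(F)c4)nn3)ccc12` was examined in a functional assay on QGY7701 cells (Homo sapiens) for cytotoxicity, read by MTT assay, with a stated time of 48 h (on this read-out higher numbers stand for weaker inhibition and lower numbers for stronger inhibition), where compound 1 gives only a limit, > 100000 nM. Compound 2 `CC(C)(C)c1ccc(Cn2cc(COc3ccc4c(=O)ccoc4c3)nn2)cc1` is likewise known only as a limit in this assay, at > 100000 nM. Both values therefore rest on (the limit of > 100000 nM in this assay, at which 2 of the 2 values shown sit). Among the measured compounds shown here, compound 3 `O=c1ccoc2cc(OCc3cn(Cc4ccccc4Br)nn3)ccc12` differs from compound 1 by 2-bromophenyl in place of 3-fluorophenyl on a saturated chain carbon bound to an aromatic nitrogen, and no step between a measured pair of this kind exists here. Given that compound 1 stands at > 100000 nM, compound 3 is expected to remain weak, with a step that the limit leaves unreadable from compound 1 to compound 3 expected to be none beyond the scatter. Compound 3 is estimated at 150000 nM, ranging from 50000 nM to 500000 nM.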

Compound 3, half-maximal inhibitory concentration: > 100000 nM
Compound 3: only a limit was reported; the forecaster's own chance of this, stated with the estimate: 80%; the middle value is on the limit's open side.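

Compound 1 and compound 3 are both known only as limits in this assay, so no step between them can be read: the limit of > 100000 nM in this assay, at which 3 of the 3 values shown sit.

The compounds shown leave open whether 2-bromophenyl and 3-fluorophenyl differ in their effect at all, since the actual potency of compound 1, compound 2 and compound 3 remains unknown.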